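A Fluoro Substituent Added to an Inactive Scaffold

The source may hold more compounds than are shown below. What is called first, only, known or untested is meant among the compounds shown, and "the series" means these compounds.

Compound 1 `NS(=O)(=O)c1ccc(Nc2ncc(F)c(Nc3nc4ccccc4s3)n2)cc1` gives > 50000 nM in a functional assay on PC-3 cells (Homo sapiens) for antiproliferative activity, read by MTT assay, with a stated time of 48 h (a lower number here means a stronger inhibitor, a higher number a weaker inhibitor), a limit of the assay.
Compound 2 `Cc1cnc(Nc2ccc(S(N)(=O)=O)cc2)nc1Nc1nc2ccccc2s1` gives > 50000 nM in this assay, also a limit.
Compound 3 `Cc1cnc(Nc2ccc(S(C)(=O)=O)cc2)nc1Nc1nc2ccccc2s1` gives > 50000 nM in this assay, again a limit.

Compound 2 therefore stands only at a limit, like every other value shown, as the limit of > 50000 nM in this assay, at which 3 of the 3 values shown sit, records. The two measured steps, a step that the two limits leave unreadable from compound 1 to compound 2 and a step that the two limits leave unreadable from compound 2 to compound 3, are consequently of unreadable size, so neither says anything about direction or magnitude. Compound 4 `Cc1cnc(Nc2ccc(S(N)(=O)=O)cc2)nc1Nc1nc2ccc(F)cc2s1` differs from compound 2 by fluoro in place of hydrogen on an aromatic carbon. With no readable step in hand, no change beyond the scatter can be expected in this assay. The step of a number no higher from compound 2 to compound 4 (the limit leaves the size open) is expected to be essentially flat. Compound 4 is estimated at 50000 nM, within 20000 nM to 100000 nM, most likely reported again as a limit.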

Compound 4, half-maximal inhibitory concentration: 6980 nM
For compound 4 the middle estimate is 7.2-fold (0.86 log units) above the measured one; measured number outside the range, below it.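

In this assay, fluoro in place of hydrogen on an aromatic carbon of the six-membered carbon-only ring gives the first readable change among these compounds: an at least 7.1-fold lower number from compound 2 to compound 4 (0.85 log units; beyond the scatter). Going by these compounds alone, this position therefore responds to a single added atom, which the earlier compounds could not show, as their steps cannot be read. Compound 2 stands only at a limit, so the full size of this step stays open: the limit of > 50000 nM in this assay, at which 3 of the 4 values shown sit.

Going by these compounds, whether chloro or methoxy on this same carbon would act like fluoro remains open. Also open, on these data alone, is whether fluoro here would lower the number for compound 3 too.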